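A few compounds are considered here, and "the series" means these few. Any claim that something is new, unique, unknown or untested is made for them only; others in the source may bear on it.

The series shares one core, carried by compound 1 `Clc1ccccc1-c1cc(-c2cnn(C3CCNCC3)c2)on1`, compound 2 `Cc1c(-c2cc(-c3ccccc3)no2)cnn1C1CCNCC1` and compound 3 `Fc1ccc(-c2cc(-c3cnn(C4CCNCC4)c3)on2)c(Cl)c1`. In an assay on a protein complex for positive allosteric modulation of Neuronal acetylcholine receptor; alpha4/beta2 (Homo sapiens) (on this read-out higher numbers stand for larger maximal responses and lower numbers for smaller maximal responses), compound 1 gives 38%, compound 2 gives 31% and compound 3 gives 56%. Compound 3 stands highest of the three, with compound 1 nearest to it and compound 2 furthest away, both gaps lying beyond the scatter. Among the compounds with values here, the one single-point step available is a number 18 percentage points higher from compound 1 to compound 3 (beyond the scatter), which came from fluoro in place of hydrogen on an aromatic carbon.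

Compound 4 `Clc1cnccc1-c1cc(-c2cnn(C3CCNCC3)c2)on1` is the next compound and is not yet measured. Against compound 3 it shows (3-chloropyridin-4-yl in place of 2-chloro-4-fluorophenyl on an aromatic carbon). Within the data shown here, no measured pair speaks to this change directly: the fluorine that enters from compound 1 to compound 3 leaves again, and a ring nitrogen enters in the six-membered aromatic ring. Among the measured compounds shown here, the only step that bears on it is the one from compound 1 to compound 3, and if the loss of the fluorine counts for most of it, compound 4 is expected to fall back toward the level of compound 1, as the estimated a number 14 percentage points lower from compound 3 to compound 4 (beyond the scatter) expresses. Compound 4 is therefore estimated at 42% in this assay, with a range from 26% to 58%.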

Compound 4, largest response reached (reported as efficacy), in percent of the reference or control that the assay uses: 50%
Compound 4: the middle estimate sits 8 percentage points below what was measured, within the range that was stated.
By their numbers in this assay, from the lowest: compounds 2 and 1 (each within the scatter of the next); then compounds 4 and 3 (each within the scatter of the next).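

In this assay the exchange of the halogenated benzene ring for the pyridine at this position, on the aromatic carbon next to the ring nitrogen, gives a number 6 percentage points lower from compound 3 to compound 4 (within the scatter) and so leaves compound 3 and compound 4 at one level. Measured against the plain 2-chlorophenyl group, 3-chloropyridin-4-yl gives a number 12 percentage points higher from compound 1 to compound 4 (beyond the scatter) and thereby shows that the gain at this position is not tied to the fluorine: a ring nitrogen in the six-membered aromatic ring, with no fluorine present, also lifts the number beyond the scatter of compound 1. Nothing in the data says why these two different changes end at levels that cannot be told apart.

On these data alone, whether fluoro and a ring nitrogen together in one ring would add up stays open, as does whether the chlorine can give way to a methyl, a methoxy or a nitrile on that ring. Compound 2 differs from the others in more than one place, so what its methyl group and its unsubstituted phenyl each contribute cannot be separated.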